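A few compounds are considered here, and "the series" means these few. Any claim that something is new, unique, unknown or untested is made for them only; others in the source may bear on it.

Measured in a functional assay on HT cells (Homo sapiens) for antiproliferative activity, read by fluorescence, with a stated time of 72 h; on this read-out lower numbers stand for stronger inhibition of growth and higher numbers for weaker inhibition of growth:
- compound 1 `CC(O)CSc1nc(NCc2ccc(-c3ccccn3)cc2)c2[nH]nc(C(C)C)c2n1`: 62 nM
- compound 2 `CSc1nc(NCc2ccc(-c3ccccn3)cc2)c2[nH]nc(C(C)C)c2n1`: 783 nM
- compound 3 `CC(C)c1n[nH]c2c(NCc3ccc(-c4ccccn4)cc3)nc(SCCN)nc12`: 22 nM

Compound 3 holds the lowest number of the three, and its gaps to the other two lie beyond the scatter. Compound 4 `CC(C)c1n[nH]c2c(NCc3ccc(-c4ccccn4)cc3)nc(SC(C)C(C)O)nc12` is not yet measured. It differs from compound 3 as follows: 2-hydroxy-1-methylpropyl in place of 2-aminoethyl on a sulfur. In words, 2-hydroxy-1-methylpropyl stands in place of 2-aminoethyl on a sulfur.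

The nearest guide is the modest 2.8-fold lower number from compound 1 to compound 3 (0.45 log units; beyond the scatter), since compound 1 also carries a hydroxyl-bearing chain where compound 3 carries an amine-bearing one. The large 13-fold higher number from compound 1 to compound 2 (1.10 log units; beyond the scatter) and the large 36-fold lower number from compound 2 to compound 3 (1.55 log units; beyond the scatter) show that the group on the sulfur can move the number strongly in this series. Among the compounds with values here, no measured compound tests the 1-methyl branch of the entering group, so the uncertainty stays wide.

A modest rise in this assay is therefore expected, landing near compound 1. The expected change is a 3.2-fold higher number from compound 3 to compound 4 (0.50 log units; beyond the scatter). For compound 4 the estimate is 70 nM, with an expected range of 25 nM to 200 nM.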

Compound 4, concentration for 50% growth inhibition: 190 nM
Estimate against measurement, compound 4: 2.7-fold (0.43 log units) below; the measured number falls inside the stated range.
By their numbers in this assay, from the lowest: compound 3; then compound 1; then compound 4; then compound 2.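

In this assay, methyl in place of hydrogen on a saturated chain carbon bound to a saturated chain carbon and a sulfur gives the first measured effect of this branch (a 3.1-fold higher number from compound 1 to compound 4 (0.49 log units; beyond the scatter)), and it weakens inhibition of growth. The branched hydroxyl chain still keeps part of the gain over methyl on the sulfur (a 4.1-fold lower number from compound 2 to compound 4 (0.62 log units; beyond the scatter)), but replacing 2-aminoethyl with 2-hydroxy-1-methylpropyl costs more than the hydroxyl-for-amine comparison alone had indicated (an 8.6-fold higher number from compound 3 to compound 4 (0.94 log units; beyond the scatter)). No available measurement accounts for these steps.

The compounds shown leave open how methyl on that same chain carbon acts in a chain ending in an amine. Also open, from the compounds shown here alone, is whether a carboxylic acid or a longer chain on the sulfur would fit the order seen here.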